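A few compounds are considered here, and "the series" means these few. Any claim that something is new, unique, unknown or untested is made for them only; others in the source may bear on it.

Compound 1 `CC(=O)c1ccc(-c2cccc(NC(=O)CCc3ccc4c(c3)B(O)OC4)c2)cc1`: 59000 nM
Compound 2 `COc1cc(OC)cc(-c2cccc(NC(=O)CCc3ccc4c(c3)COB4O)c2)c1`: 77000 nM

In a functional assay on MDA-MB-231 cells (Homo sapiens) for antiproliferative activity, read by MTT assay, with a stated time of 72 h (a lower number here means a stronger inhibitor, a higher number a weaker inhibitor), compound 2 gives 77000 nM. That number lies within the usual scatter of compound 1 at 59000 nM, so the two values cannot be told apart. Compound 3 `CC(=O)c1ccc(-c2cccc(NC(=O)CCc3ccc4c(c3)COB4O)c2)cc1` has 4-acetylphenyl in place of the 3,5-dimethoxyphenyl of compound 2, on an aromatic carbon, meta to a large group (4-acetylphenyl in place of 3,5-dimethoxyphenyl on an aromatic carbon). Within the data shown here, no two measured compounds differ in just one place, so nothing measured yet shows what a single swap does in this assay. With so little to go on, the expectation rests on compound 2 at 77000 nM, and no step beyond the scatter is expected, in either direction. The estimated change is a 1.2-fold lower number from compound 2 to compound 3 (0.07 log units; within the scatter). For compound 3 the expected value is 65000 nM, with an estimated range from 28000 nM to 130000 nM.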

Compound 3, half-maximal inhibitory concentration: 66000 nM
Estimate against measurement, compound 3: 1.0-fold (0.01 log units) below, and the stated range covers the measured number.
By their numbers in this assay, from the lowest: compounds 1, 3 and 2 (each within the scatter of the next).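

In this assay, exchanging 3,5-dimethoxyphenyl for 4-acetylphenyl, meta to a large group, gives a 1.2-fold lower number from compound 2 to compound 3 (0.07 log units; within the scatter), so these two groups cannot be told apart at this position. On a saturated chain carbon, two bonds along the chain from a carbonyl carbon, exchanging one group of 10 heavy atoms for another with the same atom and ring counts gives a 1.1-fold higher number from compound 1 to compound 3 (0.05 log units; within the scatter), so this change also leaves no readable difference. Nothing measured here explains why either change has so little effect.

Going by these compounds, both steps keep a large group at the changed place, so a much smaller group remains untested here. An amine or a carboxylic acid on the outer ring, or a longer chain leading to the carbonyl, could still show whether these positions can move the number beyond the scatter.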